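Furan ring position shift at the amide terminus

The source may report more compounds than this note shows. Statements on the series, on what has been measured and on what is new or still open speak of the compounds shown alone.

Measured so far:
compound 1 `CCCCCCCCCCCC[C@@H](O)[C@H]1CC[C@H]([C@H](O)CCCCCCCCCCNC(=O)c2cccs2)O1` — 1820 nM
compound 2 `CCCCCCCCCCCC[C@@H](O)[C@H]1CC[C@H]([C@H](O)CCCCCCCCCCNC(=O)c2ccco2)O1` — 15800 nM

In a functional assay on OVCAR-4 cells (Homo sapiens) for inhibition, read by colorimetric assay and sulforhodamine B assay, with a stated time of 48 h (a lower number here means a stronger inhibitor of growth, a higher number a weaker inhibitor of growth), compound 2 gives the higher of the two numbers; compound 1 lies an 8.7-fold higher number from compound 1 to compound 2 (0.94 log units; beyond the scatter) away. Compound 3 `CCCCCCCCCCCC[C@@H](O)[C@H]1CC[C@H]([C@H](O)CCCCCCCCCCNC(=O)c2ccoc2)O1` differs from compound 2 by furan-3-yl in place of furan-2-yl on a carbonyl carbon, the two having the same atoms joined differently. Among the measured compounds shown here, no measured step changes the attachment point of a five-membered aromatic ring; the only step known, from thiophen-2-yl to furan-2-yl, is of a different kind, so it sets no direction here. Compound 3 is expected to stay near compound 2, with a 1.3-fold lower number from compound 2 to compound 3 (0.12 log units; within the scatter) as the expected step. The estimate for compound 3 is 12000 nM, between 4000 nM and 40000 nM.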

Compound 3, concentration for 50% growth inhibition: 74100 nM
The estimate for compound 3 lay 6.2-fold (0.79 log units) below the measured number; the whole stated range lies below it.
By their numbers in this assay, from the lowest: compound 1; then compound 2; then compound 3.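

In this assay, the attachment point of the ring on the carbonyl carbon matters in its own right: with the same atoms joined differently, the series shows a 4.7-fold higher number from compound 2 to compound 3 (0.67 log units; beyond the scatter), a change the earlier thiophen-2-yl to furan-2-yl step could not reveal. Taken together, the hetero atom and the attachment point span a wider range, with a 41-fold higher number from compound 1 to compound 3 (1.61 log units; beyond the scatter), so thiophen-2-yl remains the best of these three amide termini. Nothing available explains this position effect.

From the compounds shown here alone, whether thiophen-3-yl would also give a higher number than thiophen-2-yl remains open. So does how a phenyl or pyridin-3-yl ring would behave on the same carbonyl carbon.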